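The source may hold more compounds than are shown below. What is called first, only, known or untested is meant among the compounds shown, and "the series" means these compounds.

Compound 1 `COc1cc(OCc2csc(-c3ccc(C(F)(F)F)cc3)n2)c2cc(-c3cn4nc(OC)sc4n3)oc2c1`: > 2 h, a limit of the assay
Compound 2 `CNC(=O)c1ccc(-c2nc(COc3cc(OC)cc4oc(-c5cn6nc(OC)sc6n5)cc34)cs2)cc1`: 0.983 h
Compound 3 `COc1cc(OCc2csc(-c3ccc(C(N)=O)cc3)n2)c2cc(-c3cn4nc(OC)sc4n3)oc2c1`: 1.38 h

In an ADME assay on microsomes from liver (Homo sapiens) for metabolic stability (on this read-out higher numbers stand for a longer-lived compound and lower numbers for a shorter-lived compound), compound 3 gives 1.38 h. Its nearest neighbour in number is compound 2, and the step between them is a 1.4-fold higher number from compound 2 to compound 3 (0.15 log units; within the scatter). Compound 1 gives > 2 h, which is a limit and not a number.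

Compound 4 `COc1cc(OCc2csc(-c3ccccc3)n2)c2cc(-c3cn4nc(OC)sc4n3)oc2c1` has hydrogen in place of carbamoyl on an aromatic carbon, turning 4-carbamoylphenyl into phenyl: hydrogen in place of carbamoyl on an aromatic carbon. For the measured compounds named here, no measured step makes this exact change. The closest ones exchange trifluoromethyl for another group on an aromatic carbon: an at least 1.4-fold lower number from compound 1 to compound 3 (0.16 log units; that floor lies within the scatter), and an at least 2.0-fold lower number from compound 1 to compound 2 (0.30 log units; that floor lies within the scatter). Both are only floors, and neither floor clears the scatter. These steps therefore give weak support for a slightly higher number once the carbamoyl is gone, and the expected size stays small: a 1.2-fold higher number from compound 3 to compound 4 (0.06 log units; within the scatter). Compound 4 is estimated at 1.6 h, with an expected range from 0.8 h to 3.2 h.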

Compound 4, half-life: 1.33 h
Estimate against measurement, compound 4: 1.2-fold (0.08 log units) above; the range from low to high includes it.
By their numbers in this assay, from the lowest: compounds 2, 4 and 3 (each within the scatter of the next). At a limit, above all of these: compound 1.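

In this assay, going from 4-carbamoylphenyl to phenyl gives a 1.0-fold lower number from compound 3 to compound 4 (0.02 log units; within the scatter), so at this place, on an aromatic carbon para to a large group, carbamoyl and hydrogen cannot be told apart. The methylcarbamoyl group cannot be told apart from hydrogen here either, with a 1.4-fold higher number from compound 2 to compound 4 (0.13 log units; within the scatter), which leaves compound 2, compound 3 and compound 4 all within the scatter of one another. Compound 1 is known only through a limit of the assay, so an at least 1.5-fold lower number from compound 1 to compound 4 (0.17 log units; that floor lies within the scatter) is only a floor, and it leaves unsettled whether trifluoromethyl differs from hydrogen here: the limit of > 2 h in this assay, at which 1 of the 4 values shown sits.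

On these data alone, whether an amine, a carboxylic acid or a longer chain at this place would shift the half-life beyond the scatter remains open. As far as these compounds go, the actual half-life of compound 1 also remains open.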